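Hydroxy to hydrogen: from compound 3 to compound 4

The source may hold more compounds than are shown below. What is called first, only, known or untested is meant among the compounds shown, and "the series" means these compounds.

In a functional assay, read by spectrophotometry, with a stated time of 5 min (a higher number here means a weaker inhibitor, a lower number a stronger inhibitor), compound 1 `COc1cc(/C=C/C(=O)C(=Cc2ccc(O)c(O)c2)C(=O)/C=C/c2ccc(O)c(OC)c2)ccc1O` gives 2200 nM and compound 2 `COc1cc(/C=C/C(=O)C(=Cc2ccccc2)C(=O)/C=C/c2ccc(O)c(OC)c2)ccc1O` gives 8580 nM. Compound 3 `CCOc1cc(/C=C/C(=O)C(=Cc2ccc(O)cc2)C(=O)/C=C/c2ccc(O)c(OCC)c2)ccc1O` gives 14800 nM, a number within the scatter of that of compound 2 and beyond the scatter from that of compound 1, on the weaker side.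

Compound 4 `CCOc1cc(/C=C/C(=O)C(=Cc2ccccc2)C(=O)/C=C/c2ccc(O)c(OCC)c2)ccc1O` differs from compound 3 as follows: hydrogen in place of hydroxy on an aromatic carbon. This is hydrogen in place of hydroxy on an aromatic carbon, para to a large group, so 4-hydroxyphenyl becomes phenyl.

Going by the values given here, one measured step bears on this change: a 3.9-fold higher number from compound 1 to compound 2 (0.59 log units; beyond the scatter), a modest step beyond the scatter, with phenyl in place of 3,4-dihydroxyphenyl. That step starts from a different group, so it is only a partial guide. Given a 3.9-fold higher number from compound 1 to compound 2 (0.59 log units; beyond the scatter), a smaller step in the same direction is expected in this assay, possibly not beyond the scatter: a 1.4-fold higher number from compound 3 to compound 4 (0.13 log units; within the scatter). The estimate for compound 4 is 20000 nM, with an expected range from 9000 nM to 45000 nM.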

Compound 4, half-maximal inhibitory concentration: 20400 nM
Compound 4: middle estimate off by 1.0-fold (0.01 log units), on the low side, and the stated range covers the measured number.
By their numbers in this assay, from the lowest: compound 1; then compounds 2, 3 and 4 (each within the scatter of the next, the first and the last beyond it).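

On the core of compound 3, hydrogen in place of hydroxy on this aromatic carbon, para to a large group, gives a 1.4-fold higher number from compound 3 to compound 4 (0.14 log units; within the scatter) in this assay and so does not separate the 4-hydroxyphenyl and phenyl compounds in this assay. The earlier step of a 3.9-fold higher number from compound 1 to compound 2 (0.59 log units; beyond the scatter) took 3,4-dihydroxyphenyl to phenyl on a different core and lay beyond the scatter, so the size of a change at this part of the molecule is not the same in the two pairs, and the pairs alone cannot say whether the group or the core accounts for that. No measurement offered here explains the result.

On these data alone, whether an amine or a carboxylic acid in place of this hydroxy would give a step beyond the scatter remains open. Also open, as far as these compounds go, is what 4-hydroxyphenyl would give on the core of compound 1.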